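The compounds below may be only part of what the source reports. "The series", "measured", "known", "first", "only" and "open" are said of these compounds alone.

Of the compounds shown here, three that share one core have been tested in a functional assay on MOLT-4 cells (Homo sapiens) for inhibition, read by sulforhodamine B assay, with a stated time of 48 h; on this read-out lower numbers stand for higher toxicity in this test and higher numbers for lower toxicity in this test. Compound 1 `CCOC(=O)[C@H](CCC(=O)O)NC(=O)c1ccc(Sc2nc3cc(N)cc(N)c3nc2-c2ccccc2)cc1` carries a sulfanyl link to an aromatic ring bearing a longer side chain. In this assay compound 1 gives < 100000 nM, which is a limit of the assay rather than a number. Compound 3 `CCOC(=O)[C@H](CCC(=O)O)NC(=O)c1ccc(CNc2nc3cc(N)cc(N)c3nc2-c2ccccc2)cc1` carries the same side chain through a benzylamino link, and in this assay compound 3 gives 34700 nM. Compound 2 `Nc1cc(N)c2nc(-c3ccccc3)c(Sc3ccc(F)cc3)nc2c1` is the smaller analogue with a (4-fluorophenyl)sulfanyl group. In this assay compound 2 gives < 100000 nM, again only a limit and not a number. Compound 2 thus sits at the limit of < 100000 nM in this assay, at which 2 of the 3 values shown sit. Compound 4 `Nc1cc(N)c2nc(-c3ccccc3)c(NCc3ccc(F)cc3)nc2c1` is the untested counterpart of compound 2, with (4-fluorobenzyl)amino in place of (4-fluorophenyl)sulfanyl on an aromatic carbon. For the measured compounds named here, no measured pair shows this exact step. Compounds 1 and 3 do show the same pair of groups on the same core: compound 1 stops at the limit. Compound 3, by contrast, gives a measurable number. By analogy, the step is expected to move toward higher toxicity, out of the limit into the measurable range, roughly as a step that the limit leaves unreadable from compound 2 to compound 4. Compound 4 is therefore estimated at 40000 nM, with a range from 15000 nM to 100000 nM.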

Compound 4, concentration lethal to 50% of the cells: < 100000 nM
Compound 4: no number, only a limit; the forecaster's own chance of this, stated with the estimate: 40%; the middle value does not contradict the limit.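

Compound 4 gives < 100000 nM, which is a limit of the assay and not a number. Compound 2 also stands only at a limit, so no step can be read between compound 2 and compound 4. The compounds shown leave open whether compound 2 and compound 4 differ in toxicity at all, and in which direction.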